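A few compounds are considered here, and "the series" means these few. Any claim that something is new, unique, unknown or untested is made for them only; others in the source may bear on it.

Going by the values given here, compound 1 `Cc1cccc(-n2cc(-c3ccccc3NS(=O)(=O)c3c[nH]c(=O)[nH]c3=O)nn2)c1` is the only member of this small set that yields an actual number in an ADME assay on L02 cells (Homo sapiens) for cytotoxicity, read by MTT assay, with a stated time of 24 h; on this read-out lower numbers stand for higher toxicity in this test and higher numbers for lower toxicity in this test: compound 1 gives 21900 nM. Compound 2 `Cc1ccc(-n2cc(-c3ccccc3NS(=O)(=O)c3c[nH]c(=O)[nH]c3=O)nn2)cc1` reaches only a limit of the assay, > 100000 nM. Compound 3 `O=c1[nH]cc(S(=O)(=O)Nc2ccccc2-c2cn(-c3ccccc3F)nn2)c(=O)[nH]1` likewise shows only a limit, > 100000 nM. Between compound 2 and compound 3 the step is a step that the two limits leave unreadable from compound 2 to compound 3. Compound 4 `O=c1[nH]cc(S(=O)(=O)Nc2ccccc2-c2cn(-c3ccccc3Cl)nn2)c(=O)[nH]1` carries 2-chlorophenyl in place of 3-methylphenyl on an aromatic nitrogen. Because both measured departures from 3-methylphenyl, an at least 4.5-fold higher number from compound 1 to compound 2 (0.65 log units; beyond the scatter) and an at least 4.5-fold higher number from compound 1 to compound 3 (0.65 log units; beyond the scatter), ended at the limit of > 100000 nM in this assay, at which 2 of the 3 values shown sit, a rise beyond the scatter is expected for this assay as well, a 4.6-fold higher number from compound 1 to compound 4 (0.66 log units; beyond the scatter), with a real chance that only a limit is reported. Compound 4 is therefore estimated at 100000 nM, expected to fall between 40000 nM and 300000 nM.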

Compound 4, half-maximal cytotoxic concentration: 22800 nM
For compound 4 the middle estimate is 4.4-fold (0.64 log units) above the measured one; measured number outside the range, below it.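

In this assay, leaving 3-methylphenyl does not by itself lift the number: 2-chlorophenyl in its place gives a 1.0-fold higher number from compound 1 to compound 4 (0.02 log units; within the scatter). The identity of the halogen on this phenyl ring matters instead, since chloro in place of fluoro gives an at least 4.3-fold lower number from compound 3 to compound 4 (0.64 log units; beyond the scatter), while 2-chlorophenyl in place of 4-methylphenyl gives an at least 4.3-fold lower number from compound 2 to compound 4 (0.64 log units; beyond the scatter). Both of these steps are bounds only, because each starts from a limit: the limit of > 100000 nM in this assay, at which 2 of the 4 values shown sit. The compounds shown leave open how an unsubstituted phenyl, a 2-methylphenyl or a 2-bromophenyl would read at this position.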